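Swapping a hydroxyphenyl for a pyrazole on the shared thiophene core

This account rests on a few compounds, and the source may have more. Where it says the series, first, only, none or still open, it means among the compounds named here.

Of the compounds shown here, three have been measured in an assay on cells for positive allosteric modulation of Cystic fibrosis transmembrane conductance regulator variant F508del (Homo sapiens), with stated times of 10 min and 7 s, in the presence of a further agent that is not named here; a higher number here means that more compound is needed for the effect, a lower number that less compound is needed. Compound 1 `Cc1ccc(C(=O)Nc2sc3c(c2C(N)=O)CCCC3)s1` gives 652 nM. Compound 2 `CC1(C)Cc2c(sc(NC(=O)c3ccccc3O)c2C(N)=O)C(C)(C)O1` gives 4 nM, the lowest of the three numbers. Compound 3 `CC1(C)Cc2c(sc(NC(=O)c3cn[nH]c3)c2C(N)=O)C(C)(C)O1` gives 125 nM; the step of a 31-fold higher number from compound 2 to compound 3 (1.49 log units; beyond the scatter) is the closest guide here, while compound 1 sits further from compound 2. Compound 4 `CC1(C)Cc2c(sc(NC(=O)c3ccn[nH]3)c2C(N)=O)C(C)(C)O1` has not been measured; it differs from compound 2 by 1H-pyrazol-5-yl in place of 2-hydroxyphenyl on a carbonyl carbon. For the measured compounds named here, the one comparable step, a 31-fold higher number from compound 2 to compound 3 (1.49 log units; beyond the scatter), also replaced the 2-hydroxyphenyl with a pyrazole and raised the number well beyond the scatter, so a rise of similar size is expected for compound 4: a 23-fold higher number from compound 2 to compound 4 (1.35 log units; beyond the scatter). The estimate for compound 4 is 90 nM, with a range from 15 nM to 500 nM.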

Compound 4, half-maximal effective concentration: 3 nM
The estimate for compound 4 lay 30-fold (1.48 log units) above the measured number; the whole stated range lies above it.
By their numbers in this assay, from the lowest: compounds 4 and 2 (each within the scatter of the next); then compound 3; then compound 1.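

In this assay, a pyrazole on this carbonyl carbon need not lose ground against 2-hydroxyphenyl: 1H-pyrazol-5-yl in its place gives a 1.3-fold lower number from compound 2 to compound 4 (0.12 log units; within the scatter) and stays level with it. How the pyrazole is attached carries the large effect, as 1H-pyrazol-5-yl in place of 1H-pyrazol-4-yl gives a 42-fold lower number from compound 3 to compound 4 (1.62 log units; beyond the scatter) on the same core. No evidence is available here to explain this difference.

From the compounds shown here alone, whether a methyl group on the pyrazole would keep the number this low remains open. So does the outcome for a carboxylic acid or an amine on this carbonyl carbon in place of the ring.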